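A few compounds are considered here, and "the series" means these few. Any claim that something is new, unique, unknown or untested is made for them only; others in the source may bear on it.

The measured compounds, all tested in a functional assay on A-375 cells (Homo sapiens) for cytotoxicity, read by MTT assay, with a stated time of 72 h, tested at 100 uM; a higher number here means more inhibition of growth at the concentration tested, a lower number less inhibition of growth:
compound 1, `N/C(=N\NC(=S)N1CCCCCC1)c1ccccn1`, for which compound 1 gives 89%;
compound 2, `Cc1cccc(/C(N)=N/NC(=S)N2CCSCC2)n1`, for which compound 2 gives 77.4%;
compound 3, `N/C(=N\NC(=S)N1CCSCC1)c1ccccn1`, for which compound 3 gives 87.8%.

Compounds 3 and 2 differ in one place, (methyl in place of hydrogen on an aromatic carbon), and in this assay this gave a number 10.4 percentage points lower from compound 3 to compound 2 (beyond the scatter). Compound 1 and compound 3 carry different cores; how the two cores differ is not broken down here. Their values in this assay lie within the scatter of each other, so no order between compound 1 and compound 3 is claimed. Compound 2 sits below both, and the gap from compound 1 to compound 2 is beyond the scatter.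

Compound 4, `Cc1ccnc(/C(N)=N/NC(=S)N2CCCCCC2)c1`, is not yet measured. It differs from compound 1 by methyl in place of hydrogen on an aromatic carbon. For the measured compounds named here, this is the same kind of change as the one from compound 3 to compound 2, but not the same: there the methyl sits next to the ring nitrogen, here it sits opposite the ring nitrogen. Because the earlier step was a number 10.4 percentage points lower from compound 3 to compound 2 (beyond the scatter), a drop of similar size is expected for compound 4, namely a number 9 percentage points lower from compound 1 to compound 4 (within the scatter), though the different place around the methyl leaves room for a smaller or larger shift. Compound 4 is therefore estimated at 80% in this assay. The expected range for compound 4 runs from 68% to 91%.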

Compound 4, percent growth inhibition at one concentration: 77%
Compound 4: the middle estimate sits 3 percentage points above what was measured; the measured number falls inside the stated range.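

In this assay, methyl in place of hydrogen on an aromatic carbon of the core of compound 1 gave a number 12 percentage points lower from compound 1 to compound 4 (beyond the scatter). Set beside the earlier case, the step carried from one core to the other with no difference in size that can be told apart: the same change on two cores in this assay, a number 10.4 percentage points lower (beyond the scatter) from compound 3 to compound 2 and a number 12 percentage points lower (beyond the scatter) from compound 1 to compound 4, 1.6 percentage points apart, within the scatter of two such steps. For the compounds shown here, this rests on only two pairs, with the methyl opposite the ring nitrogen in compound 4 and at another place on the ring in compound 2, so it shows that the step held on these two cores, but not that it would hold on other cores, and it gives no reason for the lower numbers.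

The compounds shown leave open whether an ethyl, a methoxy group, a chlorine or an amine on the same aromatic carbon would give a step of similar size, since methyl is the only group that enters in either pair. They also leave open whether methyl at the remaining carbons of the ring would follow the same course, and whether either step would persist at lower concentrations in this assay.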